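A methoxy group added at the edge of an inactive scaffold

The compounds below may be only part of what the source reports. "The series", "measured", "known", "first", "only" and "open" are said of these compounds alone.

Compound 1, `COc1ccccc1/C=C/C=N/N1C(=S)NC2C1N(C)C(=O)N2c1ccccc1`: > 100000 nM (a limit of the assay)
Compound 2, `CCN1C(=O)N(CC)C2C1NC(=S)N2/N=C/C=C/c1ccccc1OC`: 610 nM
Compound 3, `CCN1C(=O)N(c2ccccc2)C2NC(=S)N(/N=C/C=C/c3ccccc3)C21`: > 100000 nM (a limit of the assay)

In a functional assay on A549 cells (Homo sapiens) for inhibition, read by MTT assay, with a stated time of 72 h (on this read-out lower numbers stand for stronger inhibition and higher numbers for weaker inhibition), compound 3 gives only a limit, > 100000 nM. Compound 3 is thus not placed on a number at all; it stands with compound 1 at the assay limit. Compound 2 alone gives a measured value, 610 nM. Two of the three results therefore sit at the limit (the limit of > 100000 nM in this assay, at which 2 of the 3 values shown sit).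

Compound 4, `CCN1C(=O)N(c2ccccc2)C2NC(=S)N(/N=C/C=C/c3ccccc3OC)C21`, differs from compound 3 in one place: methoxy in place of hydrogen on an aromatic carbon. Going by the values given here, the same methoxy is present in compound 1, which gives a limit, and in compound 2, which gives a number; as compound 2 differs from compound 3 in more than one place, no step between them can be read.

Since compound 3 starts at a limit, the step of an at least 1.6-fold lower number from compound 3 to compound 4 (0.22 log units; that floor lies within the scatter) is expected to be uncertain, with most of its weight staying at the limit. Compound 4 is estimated at 60000 nM, within 3000 nM to 300000 nM, in this assay.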

Compound 4, half-maximal inhibitory concentration: > 100000 nM
Compound 4: no number, only a limit; the forecaster's own chance of this, stated with the estimate: 65%; middle value at least 1.6-fold (0.22 log units) away from the limit.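

In this assay compound 4 gives only a limit, so methoxy in place of hydrogen on an aromatic carbon does not bring this scaffold onto a measured number, and the steps to compound 4 from compound 3 and from compound 1 cannot be read. Phenyl in place of ethyl on an amide-type nitrogen in a ring, by contrast, goes with an at least 160-fold higher number from compound 2 to compound 4 (2.21 log units; beyond the scatter). Among the compounds shown, compound 1, compound 3 and compound 4 all carry that phenyl and all stay at the limit, while compound 2 carries ethyl there and gives the only measured value: the limit of > 100000 nM in this assay, at which 3 of the 4 values shown sit.

On these data alone, how far beyond the limit compound 1, compound 3 and compound 4 lie remains unknown, as does whether the methoxy contributes anything to the value of compound 2. Also open, as far as these compounds go, is how a propyl chain or a benzyl group on that nitrogen would read, or an amine in place of the methoxy.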